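Exchanging a Cyano-Methoxyphenoxy Chain End for Phenylsulfanyl

This account rests on a few compounds, and the source may have more. Where it says the series, first, only, none or still open, it means among the compounds named here.

Of the compounds shown here, three have so far been measured in a functional assay (aorta) with Oryctolagus cuniculus as the target; a lower number here means tighter binding, a higher number weaker binding. Compound 1 `COc1cc(C(C)=O)ccc1OCCCN1CCC(C(c2ccc(F)cc2)c2ccccn2)CC1` gives 158 nM in this assay. Compound 2 `COc1cc(C(C)=O)ccc1OCCCN1CCC(C(N)(c2ccc(F)cc2)c2ccc(F)cc2)CC1` gives 31.6 nM in this assay. Compound 3 `COc1cc(C#N)ccc1OCCCN1CCC(C(c2ccc(F)cc2)c2ccc(F)cc2)CC1` gives 2 nM in this assay, the lowest of the three numbers; its gap to compound 2, the nearest of the other two, and its gap to compound 1, the furthest, both lie beyond the usual scatter of repeated measurements, so compound 3 stands as the tightest binder of the set. Within the data shown here, no two of the measured compounds differ in a single place, so no measured step is available to lean on.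

Compound 4 `Fc1ccc(C(c2ccc(F)cc2)C2CCN(CCCSc3ccccc3)CC2)cc1` has not yet been measured. It differs from compound 3 in one place: phenylsulfanyl in place of 4-cyano-2-methoxyphenoxy on a saturated chain carbon, three bonds along the chain from an amine nitrogen in a ring. Among the measured compounds shown here, nothing among the measured compounds shows what this exchange on the chain does, and the whole substituted aryl ether end that compound 3 carries is gone in compound 4. A step toward a higher number in this assay, beyond the scatter, is expected rather than a neutral one. Compound 4 is therefore expected to give about 15 nM, with a range from 3 nM to 80 nM, which corresponds to an expected step of a 7.5-fold higher number from compound 3 to compound 4 (0.88 log units; beyond the scatter).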

Compound 4, dissociation constant: 3.16 nM
For compound 4 the middle estimate is 4.7-fold (0.68 log units) above the measured one; the range from low to high includes it.
By their numbers in this assay, from the lowest: compounds 3 and 4 (each within the scatter of the next); then compound 2; then compound 1.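

In this assay, phenylsulfanyl in place of 4-cyano-2-methoxyphenoxy on a saturated chain carbon, three bonds along the chain from an amine nitrogen in a ring, amounts to a 1.6-fold higher number from compound 3 to compound 4 (0.20 log units; within the scatter), so the two compounds cannot be told apart in this read-out. Among these compounds, this is the first step in the set that changes a single place, and it shows that the chain end tolerates a large exchange: the nitrile and the methoxy group both leave, sulfur takes the place of the aryl ether oxygen, and the entering group is smaller and has fewer hydrogen-bond acceptors, yet the number stays within the scatter. Nothing available explains why so large an exchange leaves the number within the scatter.

The compounds shown leave open whether the sulfur or the loss of the ring substituents matters on its own, since an unsubstituted phenoxy end or a phenylsulfanyl end carrying a nitrile would separate the two. They also leave open how far this tolerance extends, for instance to a sulfonyl group in place of the sulfur or to a longer chain.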